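Swapping Methoxy for Chloro on a Shared Piperazine Scaffold

The compounds below may be only part of what the source reports. "The series", "measured", "known", "first", "only" and "open" are said of these compounds alone.

Of the compounds shown here, three have so far been measured in a functional assay on MCF7 cells (Homo sapiens) for cytotoxicity, read by MTT assay, with a stated time of 24 h; a higher number here means a weaker inhibitor, a lower number a stronger inhibitor. Compound 1, `COc1ccc(N2CCN(CC(=O)N3CCN(c4nnc(-c5ccccc5)c(-c5ccccc5)n4)CC3)CC2)cc1`, reaches only a limit of the assay, > 910000 nM, and no number. Compound 2, `O=C(CN1CCN(c2ccc(Cl)cc2)CC1)N1CCN(c2nnc(-c3ccccc3)c(-c3ccccc3)n2)CC1`, gives 56300 nM. The two differ in a single spot, namely (chloro in place of methoxy on an aromatic carbon), and this change brought an at least 16-fold lower number from compound 1 to compound 2 (1.20 log units; beyond the scatter). Compound 3, `COc1ccc(-c2nnc(N3CCN(C(=O)CN4CCN(c5ccc(OC)cc5)CC4)CC3)nc2-c2ccc(OC)cc2)cc1`, likewise reaches only a limit, > 821000 nM. Compound 3 carries the same amide-linked piperazine chain as compound 1, but the difference between the two cores is not broken down here.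

Compound 4, `COc1ccc(-c2nnc(N3CCN(C(=O)CN4CCN(c5ccc(Cl)cc5)CC4)CC3)nc2-c2ccc(OC)cc2)cc1`, has not yet been measured. It differs from compound 3 by chloro in place of methoxy on an aromatic carbon, and the place described for this change is word for word the same as for the change from compound 1 to compound 2, so it is the same change on a different core. Because the earlier pair showed an at least 16-fold lower number from compound 1 to compound 2 (1.20 log units; beyond the scatter), a step of similar direction is expected here, although the starting value for compound 3 is a limit rather than a number, so the size of the step can only be estimated. For compound 4 the expected step in this assay is an at least 10-fold lower number from compound 3 to compound 4 (1.01 log units; beyond the scatter). Compound 4 is therefore estimated at 80000 nM, with a plausible range from 20000 nM to 400000 nM.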

Compound 4, half-maximal inhibitory concentration: 607000 nM
For compound 4 the middle estimate is 7.6-fold (0.88 log units) below the measured one; the measured number lies above the stated range.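

In this assay, replacing the 4-methoxyphenyl group of compound 3 with the 4-chlorophenyl group of compound 4 gives an at least 1.3-fold lower number from compound 3 to compound 4 (0.13 log units; that floor lies within the scatter), a smallest possible step rather than a measured size. For compound 3, the value > 821000 nM is a limit of the assay and not a number. Both steps for this change are written as lower numbers, but this does not show that the size of the step carries from one core to the other, nor does it show that the two sizes differ: the same change on two cores in this assay, an at least 16-fold lower number (1.20 log units; beyond the scatter) from compound 1 to compound 2 and an at least 1.3-fold lower number (0.13 log units; that floor lies within the scatter) from compound 3 to compound 4; the limit leaves it open whether they differ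

The compounds shown carry only methoxy or chloro at this place on the aromatic ring, leaving open how another group there, such as fluoro, nitrile or an amine, would read in this assay on either core. Also open, as far as these compounds go, are the actual numbers for compound 1 and compound 3, and whether the same change from 4-methoxyphenyl to 4-chlorophenyl would give a lower number on a third core, such as one whose two phenyl rings carry chloro instead of methoxy.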